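The source may report more compounds than this note shows. Statements on the series, on what has been measured and on what is new or still open speak of the compounds shown alone.

Of the compounds shown here, three have so far been tested in a functional assay on HeLa cells (Homo sapiens) for cytotoxicity, with a stated time of 72 h; on this read-out higher numbers stand for lower toxicity in this test and lower numbers for higher toxicity in this test. Compound 1 `CCCCCCCCCCCC/C=C\N(NC(=O)COC)C(=O)CCCCCCCCC` gives 108000 nM in this assay. Compound 3 `CCCCCCCCCCN(NC(=O)COC)C(=O)OC(C)(C)C` gives 104000 nM, which sits within the scatter of the value for compound 1, so these two numbers cannot be told apart. Compound 2 `CCCCCCCCCCN(NC(=O)COC)C(=O)CCCCCCCCC` reaches only the limit of this assay, > 125000 nM. Going by the values given here, the single step between measured compounds, an at least 1.2-fold lower number from compound 2 to compound 3 (0.07 log units; that floor lies within the scatter), starts from that limit of > 125000 nM in this assay, at which 1 of the 3 values shown sits, and stays within the scatter. Compound 4 `CCCCCCCCCCCC/C=C\N(NC(C)=O)C(=O)CCCCCCCCC` differs from compound 1 by hydrogen in place of methoxy on a saturated chain carbon bound to a carbonyl carbon. Among the compounds with values here, no measured step touches this part of the molecule, so no shift beyond the scatter is expected. The step expected is no change at the digits printed from compound 1 to compound 4 (within the scatter). Compound 4 is therefore expected to give about 108000 nM, with a range from 54000 nM to 216000 nM.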

Compound 4, half-maximal cytotoxic concentration: 83300 nM
Beside the measured number, compound 4's estimate is 1.3-fold (0.11 log units) above it; the measured number falls inside the stated range.
By their numbers in this assay, from the lowest: compounds 4, 3 and 1 (each within the scatter of the next). At a limit, above all of these: compound 2.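

Replacing methoxy with hydrogen on this saturated chain carbon bound to a carbonyl carbon gives a 1.3-fold lower number from compound 1 to compound 4 (0.11 log units; within the scatter) in this assay. Going by these compounds alone, this is the first measured change at this part of the molecule, and it shows that the methoxy can be removed without a change that stands out from the scatter of this test. Nothing measured here gives a cause for this result.

On these data alone, whether an amine or a carboxylic acid at this same place would shift the number stays open. So does the effect of a longer chain there.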